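Tert-butylphenyl in place of dimethylphenyl on a thiourea benzoate

A few compounds are considered here, and "the series" means these few. Any claim that something is new, unique, unknown or untested is made for them only; others in the source may bear on it.

Compound 3 `Cc1ccc(CC(CN/C(S)=N/Cc2ccc(NS(C)(=O)=O)cc2)COC(=O)c2ccccc2)cc1C` gives the highest of the three numbers in a functional assay on CHO cells with transient receptor potential cation channel subfamily V member 1 (Rattus norvegicus) as the target (a lower number here means that less compound is needed, a higher number that more compound is needed for the effect), at 1730 nM. Compound 2 `CC(=O)Nc1ccc(C/N=C(\S)NCC(COC(=O)C(C)(C)C)Cc2ccc(C)c(C)c2)cc1` gives 450 nM, and compound 1 `COc1cc(CNC(=S)NCC(COC(=O)C(C)(C)C)Cc2ccc(C)c(C)c2)ccc1O` gives 1.97 nM; both of these gaps to compound 3 lie beyond the scatter. Compound 4 `CC(C)(C)c1ccc(CC(CN/C(S)=N/Cc2ccc(NS(C)(=O)=O)cc2)COC(=O)c2ccccc2)cc1` differs from compound 3 in one place: 4-(tert-butyl)phenyl in place of 3,4-dimethylphenyl on a saturated chain carbon, three bonds along the chain from an amine nitrogen and an oxygen next to a carbonyl group. Within the data shown here, no measured pair shows this particular change, so the expected step rests only on the structures themselves. A modest step toward a lower number in this assay is expected, a 2.9-fold lower number from compound 3 to compound 4 (0.46 log units; beyond the scatter), although a result within the scatter would not be surprising. Compound 4 is therefore estimated at 600 nM, with a range from 150 nM to 2500 nM.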

Compound 4, half-maximal effective concentration: 2790 nM
The estimate for compound 4 lay 4.7-fold (0.67 log units) below the measured number; the whole stated range lies below it.
By their numbers in this assay, from the lowest: compound 1; then compound 2; then compounds 3 and 4 (each within the scatter of the next).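

In this assay, 4-(tert-butyl)phenyl in place of 3,4-dimethylphenyl gives a 1.6-fold higher number from compound 3 to compound 4 (0.21 log units; within the scatter). Among these compounds, this is the first comparison that differs in one place, and it does not separate the two groups at this position, even though the group entering has 10 heavy atoms and the one leaving has 8. No evidence bearing on this result is available.

On these data alone, it remains open whether the same exchange would read alike with the ester and the other end of compound 1. As far as these compounds go, how a plain phenyl or a 4-chlorophenyl group would read at this position also remains open.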